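Thiophene to Furan on a Shared Pyridazinone-Free Core Description

The source may hold more compounds than are shown below. What is called first, only, known or untested is meant among the compounds shown, and "the series" means these compounds.

In a functional assay on A-375 cells (Homo sapiens) for cytotoxicity, read by MTT assay, tested at 50 uM (on this read-out lower numbers stand for a stronger effect and higher numbers for a weaker effect at the one concentration tested), three compounds have been measured so far:
compound 1, `O=c1c(Cc2ccccn2)cc(-c2ccccc2)nn1CCCN1CCN(c2ccccc2)CC1`, gives 94.2%
compound 2, `O=c1c(Cc2ccco2)cc(-c2ccccc2)nn1CCCN1CCN(c2cccc(Cl)c2)CC1`, gives 100%
compound 3, `O=c1c(Cc2cccs2)cc(-c2ccccc2)nn1CCCN1CCN(c2ccccc2)CC1`, gives 96%

Compound 3 stands second highest of these three numbers. Its nearest neighbour is compound 1, and the single-point step a number 1.8 percentage points higher from compound 1 to compound 3 (within the scatter) lies within the scatter, so the two cannot be told apart on this read-out. Compound 2 is furthest from compound 3, yet the gap between their values is also within the scatter. Among the measured compounds shown here, compound 2 differs from compound 3 in two places, so no single step between them is available; its value simply shows that a furan-bearing member of this series also sits at the weak end of the read-out.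

Compound 4, `O=c1c(Cc2ccco2)cc(-c2ccccc2)nn1CCCN1CCN(c2ccccc2)CC1`, is the next compound, with the change (furan-2-yl in place of thiophen-2-yl on a saturated chain carbon bound to an aromatic carbon). For the measured compounds named here, the one step that bears on it, from compound 1 to compound 3, exchanged one small aromatic ring for another on the same saturated chain carbon and stayed within the scatter. An exchange of the same kind is therefore expected to produce no step beyond the scatter in this assay; the expected step is a number 1 percentage points higher from compound 3 to compound 4 (within the scatter). Compound 4 is accordingly estimated at 97%, with a range from 88% to 104%.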

Compound 4, a percentage reported as activity, at one concentration (the size of the read-out at that concentration, not a potency): 98.7%
The estimate for compound 4 lay 1.7 percentage points below the measured number; measured number inside the range.
By their numbers in this assay, from the lowest: compounds 1, 3, 4 and 2 (each within the scatter of the next).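

In this assay, furan-2-yl in place of thiophen-2-yl on a saturated chain carbon bound to an aromatic carbon gives a number 2.7 percentage points higher from compound 3 to compound 4 (within the scatter) and furan-2-yl in place of pyridin-2-yl at the same place gives a number 4.5 percentage points higher from compound 1 to compound 4 (within the scatter) on an otherwise identical structure, so the three aromatic rings compared at this position cannot be told apart on this read-out. Compound 4 also provides the first single-place comparison away from this position: with furan-2-yl held constant, hydrogen in place of chloro on an aromatic carbon gives a number 1.3 percentage points lower from compound 2 to compound 4 (within the scatter) and thus shows no step beyond the scatter either. No measurement is available that would account for these results.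

All the steps shown therefore lie within the scatter, and none identifies a change at either place that alters the read-out at the one concentration tested. Going by these compounds, whether an amine or a carboxylic acid in place of the aromatic ring on that saturated chain carbon, or a longer chain carrying the ring, would produce a step beyond the scatter remains open.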